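This account rests on a few compounds, and the source may have more. Where it says the series, first, only, none or still open, it means among the compounds named here.

In a functional assay on Bel-7402 cells (Homo sapiens) for inhibition, read by MTT assay, with a stated time of 24 h, tested at 10 ug/mL (on this read-out lower numbers stand for less inhibition of growth and higher numbers for more inhibition of growth at the one concentration tested), compound 1 (`O=C(CCCCC(S)CCS)Nc1ccccc1`) gave 3.72% as the only figure so far. Compound 2 (`CC(=O)SCCC(CCCCC(=O)Nc1cccc(Cl)c1)SC(C)=O`) was recorded as "not active" (no number reported) with no number attached. Compound 3 (`O=C(CCCCC(CCSC(=O)c1ccccc1)SC(=O)c1ccccc1)Nc1ccccc1`) was likewise recorded as "not active" (no number reported) in the same test. Compound 3 therefore has no single number to its name. It shares this position with compound 2, the one further entry without a figure, and it cannot be placed numerically against compound 1.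

Compound 4 (`O=C(CCCCC(CCSC(=O)c1ccccc1)SC(=O)c1ccccc1)Nc1cccc(Cl)c1`) differs from compound 3 by chloro in place of hydrogen on an aromatic carbon, which turns the phenylcarbamoyl into (3-chlorophenyl)carbamoyl. For the measured compounds named here, no measured pair isolates this change, so its size can only be judged indirectly. Compound 2 already carries the 3-chlorophenyl group and still stands as "not active" (no number reported) in this assay on the record. No step beyond the usual scatter is therefore expected from this change, in either direction, and a further report without a number is quite possible. The growth inhibition of compound 4 is estimated at 3% within an expected range from 0% to 12% if a number is reported at all.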

Compound 4, percent growth inhibition at one concentration: "not active" (no number reported)
No number was reported for compound 4, and the estimate cannot be compared.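

In this assay compound 3 and compound 4 both stand as not active with no number reported, and no step can be read between them. Nothing on record bears on this result. The compounds shown leave open whether phenylcarbamoyl to (3-chlorophenyl)carbamoyl changes growth inhibition by any measurable amount on the shared core.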